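Swapping the Base on Compound 2: Expected Cytotoxicity

The source may report more compounds than this note shows. Statements on the series, on what has been measured and on what is new or still open speak of the compounds shown alone.

In a functional assay on MT4 cells (Homo sapiens) for cytotoxicity (on this read-out lower numbers stand for higher toxicity in this test and higher numbers for lower toxicity in this test), compound 2 `CC(C)(C)[Si](C)(C)OC[C@H]1O[C@@H](n2cnc3ncnc(O)c32)[C@H](O[Si](C)(C)C(C)(C)C)[C@]12OS(=O)(=O)C=C2N` gives 15000 nM, and compound 1 `CC(C)(C)[Si](C)(C)OC[C@H]1O[C@@H](n2cnc3cncnc32)[C@H](O[Si](C)(C)C(C)(C)C)[C@]12OS(=O)(=O)C=C2N` gives 13000 nM; the two values lie within the usual scatter of each other. Compound 3 `CNc1ncnc2c1ncn2[C@@H]1O[C@H](CO[Si](C)(C)C(C)(C)C)[C@@]2(OS(=O)(=O)C=C2N)[C@H]1O[Si](C)(C)C(C)(C)C` differs from compound 2 by a group of 11 heavy atoms (6 carbon, 5 nitrogen; one five-membered aromatic ring with 2 hetero atoms, one six-membered aromatic ring with 2 hetero atoms) in place of a group of 10 heavy atoms (5 carbon, 4 nitrogen, 1 oxygen; one five-membered aromatic ring with 2 hetero atoms, one six-membered aromatic ring with 2 hetero atoms), on a saturated ring carbon. Among the measured compounds shown here, the only comparable step on this carbon, a 1.2-fold higher number from compound 1 to compound 2 (0.06 log units; within the scatter), stayed within the scatter. For compound 3 no step beyond the scatter is therefore expected, a 1.1-fold lower number from compound 2 to compound 3 (0.03 log units; within the scatter). Compound 3 is estimated at 14000 nM, with a range from 7000 nM to 28000 nM.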

Compound 3, half-maximal cytotoxic concentration: 14000 nM
Estimate against measurement, compound 3: no gap at the digits printed, and the stated range covers the measured number.
By their numbers in this assay, from the lowest: compounds 1, 3 and 2 (each within the scatter of the next).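

In this assay, a third group at this saturated ring carbon again gives no step beyond the scatter: a 1.1-fold lower number from compound 2 to compound 3 (0.03 log units; within the scatter), and a 1.1-fold higher number from compound 1 to compound 3 (0.03 log units; within the scatter). Methylamino in place of hydrogen on an aromatic carbon of the group therefore leaves the number within the scatter of both earlier compounds. Nothing measured here offers a reason for this. Still open, on these data alone, is whether a plain amino group or a longer chain on that nitrogen, such as butylamino, would give a step beyond the scatter.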